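This account rests on a few compounds, and the source may have more. Where it says the series, first, only, none or still open, it means among the compounds named here.

Working notes on the series built on the core of compound 1 (`COC(=O)/C(=C/c1ccccc1)CN1C(=O)[C@@H](OC)[C@H]1c1ccc(Cl)cc1`). Among the measured compounds shown here, in an ADME assay on cells (Epithelial cell, Homo sapiens) for antiproliferative activity, read by MTT assay, with a stated time of 48 h (on this read-out higher numbers stand for weaker inhibition and lower numbers for stronger inhibition), compound 1 gives 37900 nM as the only number so far. Compound 2 (`COC(=O)/C(=C/c1ccccc1)CN1C(=O)[C@@H](OC)[C@H]1c1cccc(Cl)c1`) has no number to stand on: in this assay compound 2 is reported as "not toxic" (no number reported) and cannot be ranked numerically. Compound 3 (`COC(=O)/C(=C/c1ccccc1)CN1C(=O)[C@@H](OC)[C@H]1c1ccc(Cl)cc1Cl`) is still unmeasured and differs from compound 2 by one change (2,4-dichlorophenyl in place of 3-chlorophenyl on a saturated ring carbon), with 2,4-dichlorophenyl in place of 3-chlorophenyl on a saturated ring carbon. The size of this step cannot be stated without a number for compound 2. The direction expected in this assay is towards stronger inhibition, with a measurable value close to that of compound 1 at 37900 nM as the sole reference. Compound 3 is expected at 30000 nM within an estimated range of 10000 nM to 90000 nM for now.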

Compound 3, half-maximal inhibitory concentration: 70000 nM
For compound 3 the middle estimate is 2.3-fold (0.37 log units) below the measured one, within the range that was stated.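

In this assay chloro in place of hydrogen on an aromatic carbon of the aryl group on the saturated ring carbon gives a 1.8-fold higher number from compound 1 to compound 3 (0.27 log units; within the scatter) and so does not separate the two compounds on this read-out. With 2,4-dichlorophenyl at this position compound 3 has a measurable value, whereas the step from the 3-chlorophenyl of compound 2 cannot be read, as compound 2 has no number. No measurement here bears on the cause of either observation.

As far as these compounds go, whether an amine or a carboxylic acid on this aryl group, in place of chloro, would give a step beyond the scatter remains open. Also open is whether a pyridyl ring in place of the phenyl ring at this position would leave the value within the scatter of these compounds.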